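Replacing butoxy with phenyl on a shared core

This account rests on a few compounds, and the source may have more. Where it says the series, first, only, none or still open, it means among the compounds named here.

Compound 1 `O/N=C(/Nc1cccc(Br)c1)c1ccc2occc2c1` is the starting point of this small set. In an assay on isolated protein for inhibition of Indoleamine 2,3-dioxygenase 1 (Homo sapiens), read by spectrophotometry (a higher number here means a weaker inhibitor, a lower number a stronger inhibitor), compound 1 gives 440 nM. Compound 2 `CC1CCN(C(=O)c2cccc(N/C(=N/O)c3ccc4occc4c3)c2)CC1` carries a (4-methylpiperidin-1-yl)carbonyl group where compound 1 has bromo. In this assay compound 2 reaches only a limit, > 30000 nM. Compound 3 `CCCCOc1cccc(N/C(=N/O)c2ccc3occc3c2)c1` carries butoxy at the same place. In this assay compound 3 also reaches only a limit, > 30000 nM. Both changes away from bromo were large: an at least 68-fold higher number from compound 1 to compound 2 (1.83 log units; beyond the scatter) and an at least 68-fold higher number from compound 1 to compound 3 (1.83 log units; beyond the scatter). Between compound 2 and compound 3 the step cannot be read, a step that the two limits leave unreadable from compound 2 to compound 3, because of the limit of > 30000 nM in this assay, at which 2 of the 3 values shown sit.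

Compound 4 `O/N=C(/Nc1cccc(-c2ccccc2)c1)c1ccc2occc2c1` is not yet measured. It differs from compound 3 in one place: phenyl in place of butoxy on an aromatic carbon. The two measured steps that bear on this change both show that a group larger than bromo at this position raised the number beyond the limit. Phenyl is another large group, so compound 4 is expected to remain weak, with an estimated step of an at least 2.0-fold lower number from compound 3 to compound 4 (0.30 log units; that floor lies within the scatter). The estimate for compound 4 in this assay is 15000 nM, between 1500 nM and 60000 nM.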

Compound 4, half-maximal inhibitory concentration: 11000 nM
For compound 4 the middle estimate is 1.4-fold (0.13 log units) above the measured one, and the stated range covers the measured number.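

Among the groups larger than bromo at this place on the ring, phenyl is the first to give a number rather than a limit in this assay, with an at least 2.7-fold lower number from compound 3 to compound 4 (0.43 log units; beyond the scatter) and an at least 2.7-fold lower number from compound 2 to compound 4 (0.43 log units; beyond the scatter). Both of these steps are only floors, because the compounds they start from stop at a limit: the limit of > 30000 nM in this assay, at which 2 of the 4 values shown sit. Phenyl still falls well short of bromo, with a 25-fold higher number from compound 1 to compound 4 (1.40 log units; beyond the scatter), so among these four compounds a large group here can keep measurable inhibition, but at a heavy cost.

Phenyl differs from butoxy both in carrying a ring and in having no oxygen, and the compounds shown do not tell which of these matters. A chloro group, a methyl group or an amine at the same place would show how the number moves with groups smaller than phenyl.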